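A Chloro for Methyl Swap on an Inactive Compound

The source may report more compounds than this note shows. Statements on the series, on what has been measured and on what is new or still open speak of the compounds shown alone.

In a functional assay on HeLa cells (Homo sapiens) for antiproliferative activity, read by MTT assay, with a stated time of 72 h (a lower number here means a stronger inhibitor, a higher number a weaker inhibitor), compound 1 `Cc1ccc(N2C(=O)COc3ccc(-c4cnc5ccccc5c4)cc32)cc1` gives > 40000 nM as its reading, and this is a limit of the assay and not a number. Compound 2 `COc1ccc(N2C(=O)COc3ccc(-c4cccc(NS(=O)(=O)c5ccc(F)cc5)c4)cc32)cc1` gives 13200 nM and compound 3 `O=C1COc2ccc(-c3cnc(Cl)c(NS(=O)(=O)c4ccc(F)cc4)c3)cc2N1C1CC1` gives 7180 nM in the same test, but both differ from compound 1 in more than one place. Compound 4 `O=C1COc2ccc(-c3cnc4ccccc4c3)cc2N1c1ccc(Cl)cc1` has chloro in place of methyl on an aromatic carbon, so 4-methylphenyl becomes 4-chlorophenyl (chloro in place of methyl on an aromatic carbon). Going by the values given here, no measured pair tests this swap. The expected size is an at least 1.1-fold lower number from compound 1 to compound 4 (0.05 log units; that floor lies within the scatter) in this assay and no step beyond the scatter is expected in either direction. Compound 4 is estimated at 35000 nM with an expected range from 15000 nM to 70000 nM in this test.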

Compound 4, half-maximal inhibitory concentration: > 40000 nM
Compound 4: no number, only a limit (the forecaster's own chance of this, stated with the estimate: 60%); at least 1.1-fold (0.05 log units) between middle value and limit.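

Compound 1 and compound 4 both stop at an assay limit and give no number, so no step can be read between them: the limit of > 40000 nM in this assay, at which 2 of the 4 values shown sit.

In this assay the compounds shown leave open whether 4-methylphenyl and 4-chlorophenyl differ at all.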